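Swapping dimethylamino for methyl on a shared core

A few compounds are considered here, and "the series" means these few. Any claim that something is new, unique, unknown or untested is made for them only; others in the source may bear on it.

Three measured compounds and one unmeasured compound share a core and differ at two places. Compound 1 `COc1cc(-c2nc(N(C)C)sc2-c2ccc3ccccc3c2)cc(OC)c1OC` carries a dimethylamino group and a naphthalen-2-yl group; in a functional assay on Jurkat cells (Homo sapiens) for antiproliferative activity, read by MTT assay, with a stated time of 72 h (on this read-out lower numbers stand for stronger inhibition and higher numbers for weaker inhibition), compound 1 gives 836 nM. Compound 2 `COc1cc(-c2nc(N(C)C)sc2-c2ccc(C)cc2)cc(OC)c1OC` keeps the dimethylamino group but carries a 4-methylphenyl group instead, a change described as 4-methylphenyl in place of naphthalen-2-yl on an aromatic carbon; in this assay compound 2 gives 6660 nM, and that change gave an 8.0-fold higher number from compound 1 to compound 2 (0.90 log units; beyond the scatter). Compound 3 `COc1cc(-c2nc(C)sc2-c2ccc3ccccc3c2)cc(OC)c1OC` keeps the naphthalen-2-yl group but carries a methyl instead of the dimethylamino group, described as methyl in place of dimethylamino on an aromatic carbon; in this assay compound 3 gives 48.6 nM, so that step was a 17-fold lower number from compound 1 to compound 3 (1.24 log units; beyond the scatter). Compound 4 `COc1cc(-c2nc(C)sc2-c2ccc(C)cc2)cc(OC)c1OC` has not yet been measured; it results from compound 2 by methyl in place of dimethylamino on an aromatic carbon. Going by the values given here, this is the same kind of change as the one from compound 1 to compound 3, but around the place the ring atom two ring bonds away bears a 4-methylphenyl group rather than a naphthalen-2-yl group, so the two steps need not match exactly. Compound 4 is expected to show a step of about a 15-fold lower number from compound 2 to compound 4 (1.17 log units; beyond the scatter), because the same kind of change gave a 17-fold lower number from compound 1 to compound 3 (1.24 log units; beyond the scatter). Compound 4 is therefore estimated at 450 nM, with a likely range from 150 nM to 1500 nM.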

Compound 4, half-maximal inhibitory concentration: 517 nM
Beside the measured number, compound 4's estimate is 1.1-fold (0.06 log units) below it, and the stated range covers the measured number.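

In this assay the swap of dimethylamino for methyl gave a 13-fold lower number from compound 2 to compound 4 (1.11 log units; beyond the scatter) and thus stronger inhibition, and its size held up when 4-methylphenyl stood in place of naphthalen-2-yl: the same change on two cores in this assay, a 17-fold lower number (1.24 log units; beyond the scatter) from compound 1 to compound 3 and a 13-fold lower number (1.11 log units; beyond the scatter) from compound 2 to compound 4, 1.3-fold (0.13 log units) apart, within the scatter of two such steps. In these two pairs, then, the change acted in the same direction and to a similar extent, whichever of the two groups was present on the other ring atom. Two pairs in one cell assay do not establish a rule for the whole series, and they do not explain why methyl gives the lower number or show that the same would hold in other cells.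

The compounds shown leave open how an ethyl group, a longer chain or an unsubstituted amine would compare with methyl and dimethylamino at this place. They also leave open whether the step would keep its size with a different group at the other place, such as an unsubstituted phenyl or a 4-methoxyphenyl.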